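This account rests on a few compounds, and the source may have more. Where it says the series, first, only, none or still open, it means among the compounds named here.

Measured compounds and their values:

Compound 1, `O=C1OC[C@H](Cc2ccccc2)[C@H]1Cc1ccccc1O`, gives 83000 nM in a functional assay on HL-60 cells (Homo sapiens) for cytotoxicity, read by WST assay, with a stated time of 48 h; on this read-out higher numbers stand for an effect only at larger amounts of compound and lower numbers for an effect already at smaller amounts.
Compound 2, `COc1ccccc1C[C@H]1C(=O)OC[C@@H]1Cc1ccccc1`, gives 79000 nM in this assay.
Compound 3, `Oc1cccc(C[C@H]2COC[C@@H]2Cc2ccc(Cl)c(Cl)c2)c1`, gives 31000 nM in this assay.

Compounds 1 and 2 share a core and differ by one change, (methyl in place of hydrogen on an oxygen on an aromatic ring). This change gave a 1.1-fold lower number from compound 1 to compound 2 (0.02 log units; within the scatter), so on this pair the two numbers cannot be told apart. Compound 3 rests on a different core; the difference between the two cores is not broken down here, and only the values can be set side by side: compound 3 gives the lowest number of the three, with its nearest neighbour compound 2 and, further away, compound 1.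

Compound 4, `COc1cccc(C[C@H]2COC[C@@H]2Cc2ccc(Cl)c(Cl)c2)c1`, has not yet been measured. It differs from compound 3 by methyl in place of hydrogen on an oxygen on an aromatic ring. The place of the change reads the same, word for word, as in the change from compound 1 to compound 2, so this is the same change applied to the core of compound 3. Since that earlier change moved the number by a 1.1-fold lower number from compound 1 to compound 2 (0.02 log units; within the scatter), the step from compound 3 to compound 4 in this assay is expected to be a 1.1-fold lower number from compound 3 to compound 4 (0.03 log units; within the scatter), that is, no real movement. On that basis compound 4 is estimated to give about 29000 nM in this assay, with a likely range from 12000 nM to 70000 nM.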

Compound 4, half-maximal effective concentration: 73000 nM
Compound 4: middle estimate off by 2.5-fold (0.40 log units), on the low side; measured number above the stated range.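

In this assay, putting methoxy in place of hydroxy gave a 2.4-fold higher number from compound 3 to compound 4 (0.37 log units; beyond the scatter), while the same change on the other core gave a 1.1-fold lower number from compound 1 to compound 2 (0.02 log units; within the scatter). Taken alone, the new step is a modest but real move, yet set beside the earlier step it cannot be called a different result: the same change on two cores in this assay, a 1.1-fold lower number (0.02 log units; within the scatter) from compound 1 to compound 2 and a 2.4-fold higher number (0.37 log units; beyond the scatter) from compound 3 to compound 4, 2.5-fold (0.39 log units) apart, within the scatter of two such steps. These two pairs therefore do not prove that the core alters what this change does, nor do they prove that the change carries over from one core to another unaltered, and they offer no explanation for the gap between the two steps.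

The compounds shown leave open what other groups would give at this place, such as an ethyl or a longer chain on the same oxygen, or an amine or a carboxylic acid in place of the hydroxy. They also leave open whether a further pair of hydroxy and methoxy compounds on a third core would side with the small step or with the larger one, which would give a firmer view of how well this change travels across the series.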